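Moving the Hydroxyl Group on the Pendant Ring

A few compounds are considered here, and "the series" means these few. Any claim that something is new, unique, unknown or untested is made for them only; others in the source may bear on it.

Of the compounds shown here, three sharing one core have been measured so far. Compound 1 `COc1cc(-n2cnc3ccc(-c4cccc(C)c4C)cc32)cc(OC)c1OC` carries a 2,3-dimethylphenyl group; in a functional assay on MCF7 cells (Homo sapiens) for antiproliferative activity, read by MTT assay, with a stated time of 72 h (a lower number here means a stronger inhibitor, a higher number a weaker inhibitor), compound 1 gives 2150 nM. Compound 2 `COc1cc(-n2cnc3ccc(-c4ccc(O)cc4)cc32)cc(OC)c1OC` carries a 4-hydroxyphenyl group instead, and compound 2 gives 4160 nM. Compound 3 `COc1cc(-n2cnc3ccc(-c4ccc(C)cc4F)cc32)cc(OC)c1OC` carries a 2-fluoro-4-methylphenyl group, and compound 3 gives 56 nM. Among these three numbers compound 1 stands second highest: the step of a 1.9-fold higher number from compound 1 to compound 2 (0.29 log units; within the scatter) lies within the scatter, while the step of a 38-fold lower number from compound 1 to compound 3 (1.58 log units; beyond the scatter) is large.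

Compound 4 `COc1cc(-n2cnc3ccc(-c4cccc(O)c4)cc32)cc(OC)c1OC` has not yet been measured. Its difference from compound 1 is 3-hydroxyphenyl in place of 2,3-dimethylphenyl on an aromatic carbon.

Within the data shown here, only one measured step bears on this change: a 1.9-fold higher number from compound 1 to compound 2 (0.29 log units; within the scatter), where a hydroxyphenyl group likewise replaced the 2,3-dimethylphenyl group, and that step stayed within the scatter. Here the entering group is 3-hydroxyphenyl rather than 4-hydroxyphenyl, and nothing measured so far separates the two. The expectation for compound 4 is therefore a step of a 1.6-fold higher number from compound 1 to compound 4 (0.21 log units; within the scatter), no larger than the scatter allows. Compound 4 is estimated at 3500 nM, with a range from 1500 nM to 8000 nM.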

Compound 4, half-maximal inhibitory concentration: 350 nM
Compound 4: middle estimate off by 10-fold (1.00 log units), on the high side; the whole stated range lies above it.
By their numbers in this assay, from the lowest: compound 3; then compound 4; then compounds 1 and 2 (each within the scatter of the next).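

Where the hydroxyl sits on the pendant ring matters in this assay: 3-hydroxyphenyl and 4-hydroxyphenyl carry the same atoms, yet the step of a 12-fold lower number from compound 2 to compound 4 (1.08 log units; beyond the scatter) separates them, so the earlier result for one hydroxyphenyl group cannot stand for the other. Swapping 2,3-dimethylphenyl for a hydroxyphenyl group therefore need not leave the number within the scatter, as the step of a 6.1-fold lower number from compound 1 to compound 4 (0.79 log units; beyond the scatter) shows, although the step of a 6.3-fold higher number from compound 3 to compound 4 (0.80 log units; beyond the scatter) leaves 3-hydroxyphenyl still behind the 2-fluoro-4-methylphenyl group. No measurement at hand explains why the placement of the hydroxyl counts for so much.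

As far as these compounds go, it remains open whether the hydroxyl itself is needed at that place on the ring, which a methoxy group or an amine in its stead on the otherwise unchanged 3-hydroxyphenyl ring would help to settle. It is also unknown whether the fluorine of compound 3 and the hydroxyl of compound 4 would work together on a single ring, or whether their contributions would fail to add up.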